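Trimming a Side Group on a Shared Core

The source may hold more compounds than are shown below. What is called first, only, known or untested is meant among the compounds shown, and "the series" means these compounds.

Of the compounds shown here, two have been tested in a functional assay on CHO cells for antagonist activity at Orexin receptor type 2 (Homo sapiens), read by FLIPR and calcium flux; a lower number here means a stronger inhibitor, a higher number a weaker inhibitor. Compound 1, `CCc1nc(OC)c2n1CCN([C@@H](C(=O)NC)c1ccccc1)C2CCc1ccc(C(F)(F)F)cc1`, gives 73 nM in this assay. Compound 2, `CCc1nc(C(=O)N(C)C)c2n1CCN([C@@H](C(=O)NC)c1ccccc1)C2CCc1ccc(C(F)(F)F)cc1`, gives 111 nM. Compound 2 therefore stands at the higher of the two numbers, though its separation from compound 1 is small: the step of a 1.5-fold higher number from compound 1 to compound 2 (0.18 log units; within the scatter) lies within the usual scatter, so the two compounds cannot be ranked with confidence.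

Compound 3, `CCc1nc(C)c2n1CCN([C@@H](C(=O)NC)c1ccccc1)C2CCc1ccc(C(F)(F)F)cc1`, has not yet been measured. It differs from compound 2 in one place: methyl in place of dimethylcarbamoyl on an aromatic carbon. The same position on the shared core is where compound 1 and compound 2 already differ, and that exchange of methoxy for dimethylcarbamoyl moved the number only within the scatter. A single within-scatter step is thin ground, but it suggests this position tolerates different groups without a large change in this assay.

The expected step of a 1.2-fold lower number from compound 2 to compound 3 (0.09 log units; within the scatter) is therefore small, with no clear direction beyond the scatter. Compound 3 is estimated at 90 nM, with a likely range from 35 nM to 250 nM.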

Compound 3, half-maximal inhibitory concentration: 24 nM
The estimate for compound 3 lay 3.8-fold (0.57 log units) above the measured number, outside the stated range (below it).
By their numbers in this assay, from the lowest: compound 3; then compounds 1 and 2 (each within the scatter of the next).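

In this assay this position turns out to be less forgiving than the first two compounds suggested: methoxy and dimethylcarbamoyl could not be told apart, yet methyl stands clearly apart from both. The step of a 4.6-fold lower number from compound 2 to compound 3 (0.67 log units; beyond the scatter) and the step of a 3.0-fold lower number from compound 1 to compound 3 (0.48 log units; beyond the scatter) both lie beyond the scatter, so compound 3 is the strongest inhibitor of the three and the position does respond to the group it carries. The exchange of dimethylcarbamoyl for methyl takes 5 heavy atoms down to 1 and removes a hydrogen-bond acceptor, but no measurement at hand connects either difference to the lower number, and nothing available explains the shift.

Among these compounds, with only three groups at this place, it remains open whether the lower number is particular to methyl or is shared by other small groups. Hydrogen, an ethyl group, a longer chain such as propyl, or an amine on this aromatic carbon would help show how far the trend runs and whether methyl is the best of its kind.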